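Replacing Methylamino with 4-Methylpiperazin-1-yl on the Shared Core

The compounds below may be only part of what the source reports. "The series", "measured", "known", "first", "only" and "open" are said of these compounds alone.

compound 1 `Cc1ccc(S(=O)(=O)Nc2ccc(CNc3nc(N(C)C)nc4ccccc34)cc2)cc1` gives 13000 nM
compound 2 `CNc1nc(NCc2ccc(NS(=O)(=O)c3ccc(C)cc3)cc2)c2ccccc2n1` gives 4900 nM

Among the measured compounds shown here, in a functional assay on SW480 cells (Homo sapiens) for inhibition, read by luminescence and resazurin assay, with a stated time of 3 days (a higher number here means a weaker inhibitor, a lower number a stronger inhibitor), compound 2 has the lower of the two numbers so far. Compound 3 `Cc1ccc(S(=O)(=O)Nc2ccc(CNc3nc(N4CCN(C)CC4)nc4ccccc34)cc2)cc1` differs from it by one swap, 4-methylpiperazin-1-yl in place of methylamino on an aromatic carbon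

For the measured compounds named here, only one measured step bears on this, and it is modest: a 2.7-fold lower number from compound 1 to compound 2 (0.42 log units; beyond the scatter) with hydrogen in place of methyl on a nitrogen. Like compound 1 at 13000 nM compound 3 has no hydrogen on that nitrogen, so a small move toward a higher number is expected. The expected result is a 1.6-fold higher number from compound 2 to compound 3 (0.21 log units; within the scatter) in this estimate. Compound 3 is expected at 8000 nM (estimated range 2000 nM to 25000 nM).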

Compound 3, half-maximal inhibitory concentration: > 20000 nM
Compound 3 ended at the assay's limit; the forecaster's own chance of this, stated with the estimate: 12%; middle value at least 2.5-fold (0.39 log units) away from the limit.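

In this assay, compound 3 gives > 20000 nM, which is a limit of the assay and not a number. On this aromatic carbon between two ring nitrogen atoms, a ring costs more than removing or adding one methyl did, with 4-methylpiperazin-1-yl in place of methylamino giving an at least 4.0-fold higher number from compound 2 to compound 3 (0.61 log units; beyond the scatter). Against dimethylamino the step is an at least 1.5-fold higher number from compound 1 to compound 3 (0.18 log units; that floor lies within the scatter), and compound 3 cannot be ordered against compound 1 because its reading is a limit: the limit of > 20000 nM in this assay, at which 1 of the 3 values shown sits.

Still open, from the compounds shown here alone, is how a plain amino group or a morpholin-4-yl ring would read here. That leaves unsettled whether the ring itself or the missing hydrogen on the nitrogen goes with the higher number.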